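A Hydroxybutyl Amide in Place of a Sulfonylpiperazine

This account rests on a few compounds, and the source may have more. Where it says the series, first, only, none or still open, it means among the compounds named here.

Three compounds share one core and differ only in the group on a carbonyl carbon attached to a saturated chain carbon. Compound 1 `CCC1CCCN(C(=O)CN2CN(c3ccccc3)C3(CCN(C(=O)c4ccc(C5CCCCC5)cc4)CC3)C2=O)C1` gives 2600 nM in an assay on HEK293 cells for displacement of a labelled ligand from NPC1-like intracellular cholesterol transporter 1 (Homo sapiens); a lower number here means a stronger inhibitor, a higher number a weaker inhibitor. Compound 2 `O=C(CN1CN(c2ccccc2)C2(CCN(C(=O)c3ccc(C4CCCCC4)cc3)CC2)C1=O)NCCO` gives 2000 nM, and compound 3 `CS(=O)(=O)N1CCN(C(=O)CN2CN(c3ccccc3)C3(CCN(C(=O)c4ccc(C5CCCCC5)cc4)CC3)C2=O)CC1` gives 6300 nM. In this assay compound 3 therefore stands highest of the three numbers: the step of a 2.4-fold higher number from compound 1 to compound 3 (0.38 log units; beyond the scatter) and the step of a 3.2-fold higher number from compound 2 to compound 3 (0.50 log units; beyond the scatter) both run upward beyond the scatter, while the step of a 1.3-fold lower number from compound 1 to compound 2 (0.11 log units; within the scatter) stays within it.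

Compound 4 `O=C(CN1CN(c2ccccc2)C2(CCN(C(=O)c3ccc(C4CCCCC4)cc3)CC2)C1=O)NCCCCO` is not yet measured. It differs from compound 3 in one place: (4-hydroxybutyl)amino in place of 4-(methylsulfonyl)piperazin-1-yl on a carbonyl carbon. The closest measured step is the one that brought in the same sulfonylpiperazine, a 3.2-fold higher number from compound 2 to compound 3 (0.50 log units; beyond the scatter), which lifted the number; the change to compound 4 removes that group again and brings in an open-chain hydroxyalkylamino group of the kind compound 2 carries. The step of a 2.4-fold higher number from compound 1 to compound 3 (0.38 log units; beyond the scatter) points the same way. The step to compound 4 is therefore expected to run downward, by about a 2.9-fold lower number from compound 3 to compound 4 (0.46 log units; beyond the scatter), landing near the region where compound 1 and compound 2 sit. The estimate for compound 4 is 2200 nM, with a range from 900 nM to 5500 nM.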

Compound 4, half-maximal inhibitory concentration: 10300 nM
Compound 4: the middle estimate sits 4.7-fold (0.67 log units) below what was measured; the measured number lies above the stated range.
By their numbers in this assay, from the lowest: compounds 2 and 1 (each within the scatter of the next); then compounds 3 and 4 (each within the scatter of the next).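

In this assay, (4-hydroxybutyl)amino in place of 4-(methylsulfonyl)piperazin-1-yl on a carbonyl carbon gives a 1.6-fold higher number from compound 3 to compound 4 (0.21 log units; within the scatter), so at this position the two groups cannot be told apart, even though one is open-chain and the other carries a ring. Going by these compounds alone, the hydroxyalkylamino groups do not behave as one class here: extending the chain of compound 2 gives a 5.2-fold higher number from compound 2 to compound 4 (0.71 log units; beyond the scatter), and (4-hydroxybutyl)amino in place of 3-ethylpiperidin-1-yl gives a 4.0-fold higher number from compound 1 to compound 4 (0.60 log units; beyond the scatter), so the length of the open chain on this carbonyl carbon matters in a way that the earlier compounds could not show. Nothing given here bears on why the number follows chain length in this way.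

The compounds shown leave open how the number moves at an intermediate chain such as 3-hydroxypropyl, and whether it keeps moving with a 5-hydroxypentyl chain. They also leave open whether the terminal hydroxy takes part at all, a question that a plain butyl amide, a methoxybutyl amide or a carboxylic acid at the end of the same chain would address.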